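Swapping methyl for 4-fluorophenyl on the carbonyl

A few compounds are considered here, and "the series" means these few. Any claim that something is new, unique, unknown or untested is made for them only; others in the source may bear on it.

Measured in a functional assay on MT4 cells (Homo sapiens) for cytotoxicity; a lower number here means that less compound is tolerated, a higher number that more compound is tolerated:
- Compound 1 `Cc1c(O)nc(SCC(=O)c2ccc(F)cc2)nc1Cc1cccc2ccccc12`: >= 275000 nM, a limit
- Compound 2 `CCc1c(O)nc(SCC(=O)c2ccc(F)cc2)nc1Cc1cccc2ccccc12`: >= 240000 nM, a limit
- Compound 3 `CC(=O)CSc1nc(O)c(C(C)C)c(Cc2cccc3ccccc23)n1`: 43000 nM

Going by the values given here, compound 3, at 43000 nM, holds the only true number here. Compound 4 `CC(C)c1c(O)nc(SCC(=O)c2ccc(F)cc2)nc1Cc1cccc2ccccc12` differs from it by 4-fluorophenyl in place of methyl on a carbonyl carbon. Among the compounds with values here, the one measured step, a step that the two limits leave unreadable from compound 1 to compound 2, has no readable size, so it offers no direct guide. Compound 1 carries the same 4-fluorophenyl, and its >= 275000 nM is a limit. Compound 2 carries it too, and its >= 240000 nM is also a limit. The expected step in this assay is therefore upward, a 3.5-fold higher number from compound 3 to compound 4 (0.54 log units; beyond the scatter), towards more compound tolerated. For compound 4 the estimated value is 150000 nM, with an expected range of 50000 nM to 300000 nM.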

Compound 4, half-maximal cytotoxic concentration: 186000 nM
For compound 4 the middle estimate is 1.2-fold (0.09 log units) below the measured one; the range from low to high includes it.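

In this assay the step of a 4.3-fold higher number from compound 3 to compound 4 (0.64 log units; beyond the scatter) gives the swap on the carbonyl carbon a readable size, with isopropyl held fixed. Going by these compounds alone, compound 4 also holds the only true number among the 4-fluorophenyl compounds, while compound 1 and compound 2 stand at limits. Against those limits, the steps of an at least 1.2-fold lower number from compound 2 to compound 4 (0.11 log units; that floor lies within the scatter) and an at least 1.4-fold lower number from compound 1 to compound 4 (0.16 log units; that floor lies within the scatter) give only floors, so no effect of the chain on the aromatic carbon can be claimed.

Open, from the compounds shown here alone, is whether an unsubstituted phenyl or a carboxylic acid on the carbonyl carbon would give a similar step. Also open, going by these compounds, is whether the step keeps its size with a chain shorter than isopropyl.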